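A ring swap on an already weak compound

A few compounds are considered here, and "the series" means these few. Any claim that something is new, unique, unknown or untested is made for them only; others in the source may bear on it.

In a functional assay on MCF7 cells (Homo sapiens) for cytotoxicity, read by WST assay, with a stated time of 72 h (a higher number here means a weaker inhibitor, a lower number a stronger inhibitor), compound 1 `COc1ccc(C2(c3ccc(O)cc3)C(=O)Nc3c2ccc(F)c3F)cc1` gives 2.1 nM; 6.3 nM; > 1000 nM (3 entries). The last of these entries for compound 1 is a limit. Compound 2 `O=C1Nc2c(ccc(F)c2F)C1(c1ccc(O)cc1)c1cccnc1` gives 63 nM. Compound 3 `O=C1Nc2c(ccc(F)c2F)C1(c1ccc(O)cc1)C1CCCCCCC1` has only a limit, > 1000 nM.

Compound 4 `O=C1Nc2c(ccc(F)c2F)C1(CC1CCCCC1)c1ccc(O)cc1` carries cyclohexylmethyl in place of cyclooctyl on a saturated ring carbon. Among the compounds with values here, the one measured step that bears on this is large and beyond the scatter: an at least 15-fold higher number from compound 2 to compound 3 (1.20 log units; beyond the scatter), where cyclooctyl replaced pyridin-3-yl. Compound 4 also has a non-aromatic ring of carbon only at this place, so it should stay close to compound 3. The expected change is none beyond the scatter, a step that the limit leaves unreadable from compound 3 to compound 4. The estimated value for compound 4 is 1500 nM, with an expected range from 300 nM to 6000 nM.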

Compound 4, half-maximal inhibitory concentration: 102 nM
Compound 4: the middle estimate sits 15-fold (1.17 log units) above what was measured, and the stated range ends above it.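

Compound 4 shows that a non-aromatic ring of carbon only at this place need not cost activity. Cyclohexylmethyl in place of cyclooctyl gives an at least 9.8-fold lower number from compound 3 to compound 4 (0.99 log units; beyond the scatter), so the choice of carbon group matters here. Cyclohexylmethyl in place of pyridin-3-yl gives a 1.6-fold higher number from compound 2 to compound 4 (0.21 log units; within the scatter), so an aromatic ring with nitrogen is not required at this place.

Cyclohexylmethyl differs from cyclooctyl in both ring size and the link to the core, and the compounds shown do not separate the two. As far as these compounds go, how a directly attached cyclohexyl or a cyclohexylethyl chain would compare remains open.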